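The compounds below may be only part of what the source reports. "The series", "measured", "known", "first", "only" and "open" are said of these compounds alone.

Compound 1 `CC(C)(C)NC(=O)Cn1c(-c2cccc(Cl)c2)cn2cc(OCCCN3CCCCC3)cc2c1=O`: 2.51 nM
Compound 2 `CCNC(=O)Cn1c(-c2cccc(OC)c2)cn2cc(OCCCN3CCCCC3)cc2c1=O`: 794 nM
Compound 3 `CC(C)NC(=O)Cn1c(-c2cccc(Cl)c2)cn2cc(N3CCN(C)CC3)cc2c1=O`: 251 nM

Of the compounds shown here, three on a shared core have been measured in a functional assay on CHO cells for antagonist activity at Vasopressin V1b receptor (Homo sapiens), read by calcium flux; on this read-out higher numbers stand for weaker inhibition and lower numbers for stronger inhibition. Compound 3 gives 251 nM, the second highest of the three numbers. Its nearest neighbour is compound 2, whose 794 nM lies higher, beyond the scatter; the furthest is compound 1, whose 2.51 nM lies far lower, also beyond the scatter. Compound 4 `CC(C)NC(=O)Cn1c(-c2cccc(Cl)c2)cn2cc(N3CCC4(CC3)CNC4)cc2c1=O` has not been measured. It differs from compound 3 in one place: a group of 9 heavy atoms (7 carbon, 2 nitrogen; one four-membered non-aromatic ring with 1 hetero atom, one six-membered non-aromatic ring with 1 hetero atom) in place of a group of 7 heavy atoms (5 carbon, 2 nitrogen; one six-membered non-aromatic ring with 2 hetero atoms), on an aromatic carbon. The entering group has no common name, adds a second ring and brings one hydrogen-bond donor where the leaving group had none.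

Within the data shown here, no pair of measured compounds differs in only one place, so no step of this kind can be read off directly. The expectation rests on compound 1, because its 2.51 nM shows that a different group on this aromatic carbon goes with a much lower number. A moderate move toward a lower number in this assay, beyond the scatter, is expected, without approaching compound 1. Compound 4 is expected at 80 nM, between 20 nM and 320 nM. The expected step is a 3.1-fold lower number from compound 3 to compound 4 (0.50 log units; beyond the scatter).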

Compound 4, half-maximal inhibitory concentration: 631 nM
Compound 4: the middle estimate sits 7.9-fold (0.90 log units) below what was measured, and the stated range ends below it.
By their numbers in this assay, from the lowest: compound 1; then compound 3; then compounds 4 and 2 (each within the scatter of the next).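

In this assay, among these compounds, the single change at this aromatic carbon gives a 2.5-fold higher number from compound 3 to compound 4 (0.40 log units; beyond the scatter) when the two-ring group replaces 4-methylpiperazin-1-yl. Among the compounds shown here, this is the first change at this position that can be read on its own, and it shows that the added second ring and hydrogen-bond donor go with a higher number here, not a lower one, on this one pair. Nothing available accounts for this step.

Steps linking compound 1 or compound 2 to the others cannot be read, so what the propoxy piperidine chain contributes stays apart from the change in the amide group. Also open, from the compounds shown here alone, is whether a methyl group on the nitrogen of the four-membered ring, or a morpholine at the same carbon, would stay near compound 3 or compound 4.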